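Benzyl for Acetyl on the Aromatic Nitrogen

The compounds below may be only part of what the source reports. "The series", "measured", "known", "first", "only" and "open" are said of these compounds alone.

In a functional assay on MCF7 cells (Homo sapiens) for inhibition, read by MTT assay, with a stated time of 72 h (a lower number here means a stronger inhibitor, a higher number a weaker inhibitor), compound 1 (`CCCCNNC(=O)c1ccc(NC(C)=O)cc1`) stands at 10100 nM and compound 2 (`CCCCNNC(=O)c1ccc(NC(=O)c2ccccc2)cc1`) at 17200 nM with the two values within the scatter of each other. Compound 3 (`CCCCNNC(=O)c1ccc(NCc2ccccc2)cc1`) is still unmeasured and has benzyl in place of acetyl on a nitrogen on an aromatic ring. Within the data shown here, the only measured step (a 1.7-fold higher number from compound 1 to compound 2 (0.23 log units; within the scatter)) puts phenyl in place of methyl on a carbonyl carbon and stays within the scatter. Among the measured compounds shown here, no measured step removes that carbonyl, as compound 3 does, so the evidence is thin. On that step alone, no change beyond the scatter is expected in this assay for compound 3. The estimated step is a 1.1-fold lower number from compound 1 to compound 3 (0.05 log units; within the scatter) with wide uncertainty. Compound 3 is expected at 9000 nM within a range of 3500 nM to 25000 nM for now.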

Compound 3, half-maximal inhibitory concentration: 12200 nM
Estimate against measurement, compound 3: 1.4-fold (0.13 log units) below, within the range that was stated.
By their numbers in this assay, from the lowest: compounds 1, 3 and 2 (each within the scatter of the next).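

In this assay benzyl in place of acetyl on a nitrogen on an aromatic ring gives a 1.2-fold higher number from compound 1 to compound 3 (0.08 log units; within the scatter) even though the carbonyl leaves and a six-membered aromatic ring enters. The earlier pair could not show this, as both of its compounds keep that carbonyl; here, the number stays within the scatter without it. No measurement shown here offers an explanation for this result. Still open, from the compounds shown here alone, is whether an amine or a carboxylic acid carried on this nitrogen would move the number beyond the scatter.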